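Removing the para chloro: expected shift for compound 4

A few compounds are considered here, and "the series" means these few. Any claim that something is new, unique, unknown or untested is made for them only; others in the source may bear on it.

The compounds measured so far in a functional assay on Raji cells (Homo sapiens) for cytotoxicity, read by CCK-8 assay, with a stated time of 24 h; on this read-out lower numbers stand for stronger inhibition and higher numbers for weaker inhibition:
compound 1 `C=CC(=O)N1C(=O)CC(c2ccc(Br)cc2)Sc2ccccc21`: 51300 nM
compound 2 `C=CC(=O)N1C(=O)CC(c2ccc(Cl)cc2)Sc2ccccc21`: 18400 nM
compound 3 `C=CC(=O)N1C(=O)CC(c2cccc(Cl)c2)Sc2ccccc21`: 47100 nM

Compound 2 gives the lowest number of the three, and both of its steps to the others are beyond the scatter, so on these numbers it is the strongest inhibitor. The step of a 2.8-fold lower number from compound 1 to compound 2 (0.45 log units; beyond the scatter) shows that chloro in place of bromo on the aromatic carbon helped, and the step of a 2.6-fold higher number from compound 2 to compound 3 (0.41 log units; beyond the scatter) shows that moving the chloro from the 4-position to the 3-position cost roughly the same amount.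

Compound 4 `C=CC(=O)N1C(=O)CC(c2ccccc2)Sc2ccccc21` takes the change one step further: hydrogen in place of chloro on an aromatic carbon. The place of the change is on an aromatic carbon of a six-membered aromatic ring of carbon only, para to a large group. Going by the values given here, no measured pair shows a halogen replaced by hydrogen, so the direction has to be inferred from the two steps above, both of which were modest and both of which showed that what sits on this ring matters. Since shrinking bromo to chloro lowered the number but removing the halogen altogether is a larger loss than shifting it, compound 4 is expected to give a modestly higher number than compound 2, on the order of a 2.2-fold higher number from compound 2 to compound 4 (0.34 log units; beyond the scatter). The estimate for compound 4 is 40000 nM, with a range from 15000 nM to 110000 nM.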

Compound 4, half-maximal inhibitory concentration: 74100 nM
Beside the measured number, compound 4's estimate is 1.9-fold (0.27 log units) below it; low and high end bracket the measured number.
By their numbers in this assay, from the lowest: compound 2; then compounds 3, 1 and 4 (each within the scatter of the next).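

In this assay, the 4-chlorophenyl to phenyl change gives the first direct view of this ring with no halogen on it. Hydrogen in place of chloro on this aromatic carbon gives up ground, with a 4.0-fold higher number from compound 2 to compound 4 (0.61 log units; beyond the scatter), a step printed as beyond the scatter, so the chloro of compound 2 does count at this place. The other two halogen compounds do not separate from the halogen-free one, with a 1.6-fold higher number from compound 3 to compound 4 (0.20 log units; within the scatter) and a 1.4-fold higher number from compound 1 to compound 4 (0.16 log units; within the scatter) both within the scatter, so a halogen on this ring does not by itself lower the number, and among these four compounds only the 4-chlorophenyl compound stands apart.

Nothing available here explains why the chloro counts at this place while the other halogen arrangements do not.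

Going by these compounds, whether a fluoro, a methyl, a methoxy or an amine on the same carbon would behave like the chloro or like hydrogen stays open. Also open, on these data alone, is whether a second chloro on this ring would lower the number further or raise it again.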